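A few compounds are considered here, and "the series" means these few. Any claim that something is new, unique, unknown or untested is made for them only; others in the source may bear on it.

Measured so far in an assay on HEK293 cells for positive allosteric modulation of metabotropic glutamate receptor 5 (Homo sapiens), read by FLIPR; a lower number here means that less compound is needed, a higher number that more compound is needed for the effect:
- compound 1, `O=C(C1CCCCC1)N1CC(c2nc(-c3cccc(F)c3)no2)C1`: 1000 nM
- compound 2, `O=C(c1ccc(F)c(F)c1)N1CC(c2nc(-c3cccc(F)c3)no2)C1`: 3200 nM
- compound 3, `O=C([C@H]1CC2CCC1C2)N1CC(c2nc(-c3cccc(F)c3)no2)C1`: 72 nM

Compound 3 gives the lowest number of the three; its nearest neighbour is compound 1, with a 14-fold lower number from compound 1 to compound 3 (1.14 log units; beyond the scatter), and compound 2 lies furthest, with a 44-fold lower number from compound 2 to compound 3 (1.65 log units; beyond the scatter). Compound 4, `CC1CCCCC1C(=O)N1CC(c2nc(-c3cccc(F)c3)no2)C1`, differs from compound 3 in one place: a group of 7 heavy atoms (7 carbon; one six-membered non-aromatic ring of carbon only) in place of a group of 7 heavy atoms (7 carbon; 2 five-membered non-aromatic rings of carbon only), on a carbonyl carbon. Within the data shown here, the step that bears on it is the one from compound 1 to compound 3, where the cyclohexyl on the carbonyl carbon gave way to the bicyclic group with a 14-fold lower number from compound 1 to compound 3 (1.14 log units; beyond the scatter). Compound 4 carries a 2-methylcyclohexyl, a six-membered ring again, so part of that gain is expected to be given back: a higher number in this assay, short of the full return to compound 1. Compound 4 is therefore estimated at 300 nM, range 100 nM to 1000 nM, a step of a 4.2-fold higher number from compound 3 to compound 4 (0.62 log units; beyond the scatter).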

Compound 4, half-maximal effective concentration in the metabotropic glutamate receptor 5 assay: 540 nM
The estimate for compound 4 lay 1.8-fold (0.26 log units) below the measured number; the range from low to high includes it.
By their numbers in the metabotropic glutamate receptor 5 assay, from the lowest: compound 3; then compounds 4 and 1 (each within the scatter of the next); then compound 2.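

In the metabotropic glutamate receptor 5 assay, with heavy atoms matched on the carbonyl carbon, 2-methylcyclohexyl in place of the bicyclic group still gives a 7.5-fold higher number from compound 3 to compound 4 (0.88 log units; beyond the scatter), so the carbon count alone does not account for the number of compound 3. In the metabotropic glutamate receptor 5 assay, methyl on the saturated ring carbon gives a 1.9-fold lower number from compound 1 to compound 4 (0.27 log units; within the scatter), no readable gain, while the saturated ring keeps its edge over the aromatic one with a 5.9-fold lower number from compound 2 to compound 4 (0.77 log units; beyond the scatter). In a physicochemical assay for solubility, read by HPLC, in phosphate buffer, with a stated time of 4 h (a higher number here means a more soluble compound, a lower number a less soluble compound), compound 3 gives 54000000 nM and compound 4 gives 180000000 nM, so the higher solubility number sits with the compound that needs more in the receptor assay.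

Going by these compounds, whether a hydroxyl or an amine on the saturated ring could pair the receptor number of compound 3 with the solubility number of compound 4 remains open.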